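Ethyl at the Linking Carbon: From Compound 1 to Compound 3

A few compounds are considered here, and "the series" means these few. Any claim that something is new, unique, unknown or untested is made for them only; others in the source may bear on it.

Compound 1 `c1cc(Nc2cc(C3CC3)[nH]n2)nc(NCc2ccc3[nH]ccc3n2)n1` was tested in an assay for inhibition of serine/threonine-protein kinase PAK 1 (Homo sapiens), read by FRET and Z'-LYTE, with stated times of 10 min and 60 min (a higher number here means a weaker inhibitor, a lower number a stronger inhibitor), where compound 1 gives 120 nM. This is the lowest of the two numbers measured. Going by the values given here, the other measured compound, compound 2 `c1cc(Nc2cc(C3CC3)[nH]n2)nc(NCc2ccc3nccn3c2)n1`, gives 360 nM in this assay, a number beyond the usual scatter from that of compound 1; no step between these two is given, so only their two values can be compared.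

Compound 3 `CC[C@H](Nc1nccc(Nc2cc(C3CC3)[nH]n2)n1)c1ccc2[nH]ccc2n1` has not yet been measured. It differs from compound 1 in one place: ethyl in place of hydrogen on a saturated chain carbon bound to an aromatic carbon and a nitrogen on an aromatic ring. Nothing measured here shows what this change does. The expected step from compound 1 to compound 3 in this assay is small, a 1.5-fold lower number from compound 1 to compound 3 (0.18 log units; within the scatter), toward a slightly stronger inhibitor, and may fall within the scatter. Compound 3 is therefore estimated at 80 nM, with a range from 25 nM to 300 nM.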

Compound 3, inhibition constant: 23 nM
The estimate for compound 3 lay 3.5-fold (0.54 log units) above the measured number; the measured number lies below the stated range.
By their numbers in this assay, from the lowest: compound 3; then compound 1; then compound 2.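

This chain carbon, bound to an aromatic carbon and a nitrogen on an aromatic ring, accepts more than hydrogen: in this assay, ethyl in place of hydrogen gives a 5.2-fold lower number from compound 1 to compound 3 (0.72 log units; beyond the scatter), which means a stronger inhibitor. Going by these compounds alone, this is the first single change that can be read here, since the two earlier compounds were linked by no step and showed nothing about this position. The data offer no explanation for why the number falls with ethyl at this carbon.

The compounds shown leave open how a methyl, a propyl or a hydroxymethyl group at this carbon would compare with ethyl, and what the mirror-image arrangement of the ethyl group would give. They also leave open whether ethyl would lower the number on the core of compound 2.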